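From pentan-3-yl to cyclopentylmethyl on a shared core

This account rests on a few compounds, and the source may have more. Where it says the series, first, only, none or still open, it means among the compounds named here.

- Compound 1 `CC(C)(C)CCOc1cccc(O)c1C(=O)/C=C/c1ccc(O)cc1`: 3140 nM
- Compound 2 `CC(C)=CCOc1cccc(O)c1C(=O)/C=C/c1ccc(O)cc1`: > 30000 nM (a limit of the assay, not a number)
- Compound 3 `CCC(CC)COc1cccc(O)c1C(=O)/C=C/c1ccc(O)cc1`: 3370 nM

All three values come from a functional assay on ACHN cells (Homo sapiens) for antiproliferative activity, read by sulforhodamine B assay; a lower number here means a stronger inhibitor of growth, a higher number a weaker inhibitor of growth. Compound 3 stands level with compound 1, since the step of a 1.1-fold higher number from compound 1 to compound 3 (0.03 log units; within the scatter) lies within the scatter. Compound 2 gives only a limit.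

The next compound is compound 4 `O=C(/C=C/c1ccc(O)cc1)c1c(O)cccc1OCCC1CCCC1`. It carries cyclopentylmethyl in place of pentan-3-yl on a saturated chain carbon bound to an oxygen on an aromatic ring.

The closest guide is the swap of neopentyl for pentan-3-yl, a 1.1-fold higher number from compound 1 to compound 3 (0.03 log units; within the scatter), which changed nothing measurable. The large steps, an at least 9.5-fold higher number from compound 1 to compound 2 (0.98 log units; beyond the scatter) and an at least 8.9-fold lower number from compound 2 to compound 3 (0.94 log units; beyond the scatter), both involve 2-methylprop-1-en-1-yl, a group absent from compound 4. No step beyond the scatter is therefore expected in this assay, and the expected step is a 1.1-fold lower number from compound 3 to compound 4 (0.05 log units; within the scatter). For compound 4 the estimated value is 3000 nM, with an expected range from 1200 nM to 8000 nM.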

Compound 4, concentration for 50% growth inhibition: 3400 nM
Compound 4: the middle estimate sits 1.1-fold (0.05 log units) below what was measured; the range from low to high includes it.
By their numbers in this assay, from the lowest: compounds 1, 3 and 4 (each within the scatter of the next). At a limit, above all of these: compound 2.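

In this assay, a five-membered carbon ring can enter this place with no measurable change against the open-chain pentan-3-yl (a 1.0-fold higher number from compound 3 to compound 4 (0.00 log units; within the scatter)). The same holds when cyclopentyl replaces tert-butyl at the end of the chain (a 1.1-fold higher number from compound 1 to compound 4 (0.03 log units; within the scatter)), so among these saturated side chains, neither branched nor ring-bearing ends separate from one another. The ring-bearing compound also stands apart from the unsaturated one (an at least 8.8-fold lower number from compound 2 to compound 4 (0.94 log units; beyond the scatter)), although that step rests on a limit of the assay and not on a number: the limit of > 30000 nM in this assay, at which 1 of the 4 values shown sits.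

The compounds shown leave open how a longer chain, a six-membered carbon ring, or an amine or carboxylic acid at the chain end would behave in this assay. They also cannot say why compound 2 stands apart from the saturated compounds.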